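Dropping a Bromo Group: What Compound 4 Should Show

This account rests on a few compounds, and the source may have more. Where it says the series, first, only, none or still open, it means among the compounds named here.

Compound 1 `COc1ccc(/C=C/c2cc(OC)cc(OC)c2/C=C/C(=O)c2cccc(Br)c2)cc1`: 8.1 ug/mL
Compound 2 `COc1ccc(/C=C/c2cc(OC)cc(OC)c2/C=C/C(=O)c2ccc(Br)cc2)cc1`: 8.3 ug/mL
Compound 3 `COc1ccc(/C=C/c2cc(OC)cc(OC)c2/C=C/C(=O)c2ccccc2C)cc1`: 5.9 ug/mL

Of the compounds shown here, three sharing one core have been tested in a functional assay on A549 cells (Homo sapiens) for antiproliferative activity, read by MTT assay, with a stated time of 48 h; on this read-out lower numbers stand for stronger inhibition and higher numbers for weaker inhibition. Compound 1 gives the second highest of the three numbers; compound 2 sits closest to it, and compound 3 furthest, yet every gap lies within the scatter. The step of a 1.0-fold higher number from compound 1 to compound 2 (0.01 log units; within the scatter) moves bromo from one place on the ring to another, the step of a 1.4-fold lower number from compound 1 to compound 3 (0.14 log units; within the scatter) swaps the bromophenyl for a methylphenyl, and the step of a 1.4-fold lower number from compound 2 to compound 3 (0.15 log units; within the scatter) does the same from the other bromo isomer. None of these changes on the ring attached to the carbonyl carbon shifts the result beyond the scatter.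

Compound 4 `COc1ccc(/C=C/c2cc(OC)cc(OC)c2/C=C/C(=O)c2ccccc2)cc1` has not yet been measured. It differs from compound 1 by hydrogen in place of bromo on an aromatic carbon. The measured steps speak to this change only indirectly: they show that the carbonyl-side ring tolerates relocation or replacement of its single substituent without a clear effect. Removing that substituent altogether is expected to behave alike, so the step of a 1.0-fold lower number from compound 1 to compound 4 (0.01 log units; within the scatter) is expected to stay within the scatter. Compound 4 is therefore estimated at 8 ug/mL, with a range from 4 ug/mL to 16 ug/mL in this assay.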

Compound 4, half-maximal inhibitory concentration: 3.9 ug/mL
Estimate against measurement, compound 4: 2.1-fold (0.31 log units) above; measured number outside the range, below it.
By their numbers in this assay, from the lowest: compounds 4, 3, 1 and 2 (each within the scatter of the next, the first and the last beyond it).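

Up to this point, the ring on the carbonyl carbon seemed indifferent to what it carried, but taking the substituent away altogether gives the first changes here to pass beyond the scatter: a 2.1-fold lower number from compound 1 to compound 4 (0.32 log units; beyond the scatter) and a 2.1-fold lower number from compound 2 to compound 4 (0.33 log units; beyond the scatter) in this assay are both modest. Moving bromo around the ring made no clear difference between compound 1 and compound 2, yet having bromo at all does separate each of them from the plain benzoyl compound, so presence counts for more here than position. Methyl does not follow the same line, since a 1.5-fold lower number from compound 3 to compound 4 (0.18 log units; within the scatter) stays within the scatter, and hydrogen in place of methyl therefore cannot be told apart from no change at all.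

On these data alone, it remains open whether other groups on this ring, such as fluoro, an amine or a carboxylic acid, would side with the bromo compounds or with compound 4. Nothing in the data shown explains why removing bromo shifts the number in this assay.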